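Swapping a hydroxyphenyl for a methoxyphenyl on a shared core

The source may hold more compounds than are shown below. What is called first, only, known or untested is meant among the compounds shown, and "the series" means these compounds.

Three compounds share a core and differ in the aryl group on a double-bonded chain carbon. In an assay on HL-60 cells for inhibition of glutathione S-transferase P (Homo sapiens), read by spectrophotometry, tested at 20 uM (a lower number here means less inhibition, a higher number more inhibition at the concentration tested (going by the name of the read-out)), compound 1 `Cc1cc(C)cc(/C=C2\CN(CC(=O)O)c3c(C)cccc3C2=O)c1` gives 17.5% and compound 2 `Cc1ccc2c(c1)C(=O)/C(=C/c1ccc(Cl)cc1)CN2CC(=O)O` gives 20.7%. Compound 3 `Cc1cccc2c1N(CC(=O)O)C/C(=C\c1cccc(O)c1)C2=O` gives 75.6% and stands highest of the three, beyond the scatter from both others. Among the compounds with values here, the only single-point step is a number 58.1 percentage points higher from compound 1 to compound 3 (beyond the scatter), a large rise on exchanging the 3,5-dimethylphenyl for the 3-hydroxyphenyl. Compound 4 `COc1ccc(/C=C2\CN(CC(=O)O)c3c(C)cccc3C2=O)cc1` differs from compound 3 by 4-methoxyphenyl in place of 3-hydroxyphenyl on a double-bonded chain carbon bound to a double-bonded ring carbon. Within the data shown here, no step with a 4-methoxyphenyl is known, so compound 4 is expected to fall back toward compounds 1 and 2, a step of a number 50.6 percentage points lower from compound 3 to compound 4 (beyond the scatter). Compound 4 is therefore estimated at 25%, within 8% to 50%.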

Compound 4, a percentage reported as inhibition, at one concentration (the size of the read-out at that concentration, not a potency): 31.5%
Compound 4: middle estimate off by 6.5 percentage points, on the low side; the range from low to high includes it.
By their numbers in this assay, from the lowest: compounds 1 and 2 (each within the scatter of the next); then compound 4; then compound 3.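

At this position, on a double-bonded chain carbon bound to a double-bonded ring carbon, this assay shows a number 44.1 percentage points lower from compound 3 to compound 4 (beyond the scatter) when 4-methoxyphenyl replaces 3-hydroxyphenyl, so the high reading of compound 3 does not carry over to this other oxygen-bearing aryl group. The 4-methoxyphenyl still differs from the 3,5-dimethylphenyl, with a number 14 percentage points higher from compound 1 to compound 4 (beyond the scatter) beyond the scatter, so three aryl groups on the same core now give three separate levels. Nothing available here accounts for these differences.

The change from compound 3 to compound 4 alters both the group and its number on the phenyl name, and a 3-methoxyphenyl or a 4-hydroxyphenyl would be needed to tell these apart. Also open, on these data alone, is how an amine, as in a 3-aminophenyl, would read at this position.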